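Swapping the Formylphenoxy Arm on a Shared Core

The compounds below may be only part of what the source reports. "The series", "measured", "known", "first", "only" and "open" are said of these compounds alone.

Compound 1 `CCOC(=O)c1c(-c2ccccc2)nn(-c2ccccc2)c1COc1ccc(C=O)cc1OC`: 60 ug/mL
Compound 2 `CCOC(=O)c1c(-c2ccccc2)nn(-c2ccccc2)c1COc1ccc(C=O)cc1`: 60 ug/mL

Of the compounds shown here, two sharing one core have been measured in an assay for inhibition of Alpha amylase (Homo sapiens), with a stated time of 30 min; on this read-out higher numbers stand for weaker inhibition and lower numbers for stronger inhibition. Compound 1 gives 60 ug/mL, and compound 2 gives 60 ug/mL. The only single-point step recorded between them is no change at the digits printed from compound 1 to compound 2 (within the scatter), so compound 2 stands level with compound 1 at the digits shown, with no change beyond the scatter.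

Compound 3 `CCOC(=O)c1c(-c2ccccc2)nn(-c2ccccc2)c1Cn1c(S)nc2ccccc21` is not yet measured. It differs from compound 2 in one place: a group of 10 heavy atoms (7 carbon, 2 nitrogen, 1 sulfur; one five-membered aromatic ring with 2 hetero atoms, one six-membered aromatic ring of carbon only) in place of a group of 9 heavy atoms (7 carbon, 2 oxygen; one six-membered aromatic ring of carbon only), on a saturated chain carbon bound to an aromatic carbon. Going by the values given here, this is a replacement of the whole arm carrying the formyl group, whereas the one measured step only removed a methoxy from that same arm. Among the compounds with values here, no measured step therefore bears on the change from compound 2 to compound 3, and the data give no ground to expect a shift in either direction beyond the scatter. On that basis compound 3 is estimated at 60 ug/mL, with a range from 20 ug/mL to 180 ug/mL, which means an expected step of no change at the digits printed from compound 2 to compound 3 (within the scatter) in this assay .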

Compound 3, half-maximal inhibitory concentration: 40 ug/mL
Beside the measured number, compound 3's estimate is 1.5-fold (0.18 log units) above it, and the stated range covers the measured number.
By their numbers in this assay, from the lowest: compounds 3, 1 and 2 (each within the scatter of the next).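

Until now only a methoxy on the arm had changed, but here the whole 4-formylphenoxy arm, on a saturated chain carbon bound to an aromatic carbon, gives way to a two-ring group holding nitrogen and sulfur, and this assay records a 1.5-fold lower number from compound 2 to compound 3 (0.18 log units; within the scatter). Set against the methoxy-bearing arm, the same swap gives a 1.5-fold lower number from compound 1 to compound 3 (0.18 log units; within the scatter), so in these three compounds neither the formyl group nor the oxygen link is needed for a number at this level, and the arm's full replacement stays within the scatter. The entering group also counts a hydrogen-bond donor where the leaving arm has none, yet nothing available explains why the numbers stay so close.

Going by these compounds, all three values lie within the scatter of one another, so it remains open whether this position can move the number at all, and an amine, a carboxylic acid or a longer alkyl chain on that same carbon would test it. Also open, on these data alone, is what the ethyl ester and the two phenyl rings of the shared core contribute, for example if a carboxylic acid or an amide took the place of the ester.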